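The compounds below may be only part of what the source reports. "The series", "measured", "known", "first", "only" and "open" are said of these compounds alone.

In a functional assay on the whole organism with Rattus norvegicus as the target (a lower number here means that less compound is needed, a higher number that more compound is needed for the effect), compound 1 `CCCn1c(=N)sc2cc(OC(F)(F)F)ccc21` gives 4.5 mg/kg. Compound 2 `CN(C)S(=O)(=O)CCn1c(=N)sc2cc(OC(F)(F)F)ccc21` does not reach a number and stops at the limit of this assay, > 10 mg/kg. Compound 3 `N=c1sc2cc(OC(F)(F)F)ccc2n1CCS(=O)(=O)O` likewise shows only a limit, > 10 mg/kg. So compound 3 stands on a limit and not on a number, and the step of an at least 2.2-fold higher number from compound 1 to compound 3 (0.34 log units; beyond the scatter) can be read only as a lower bound; the same holds for an at least 2.2-fold higher number from compound 1 to compound 2 (0.34 log units; beyond the scatter), while a step that the two limits leave unreadable from compound 2 to compound 3 cannot be read at all, since both ends sit at the limit of > 10 mg/kg in this assay, at which 2 of the 3 values shown sit.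

Compound 4 `N=c1sc2cc(OC(F)(F)F)ccc2n1CCSc1ccccc1` is the one still to be measured: phenylsulfanyl in place of sulfo on a saturated chain carbon, two bonds along the chain from an aromatic nitrogen. The entering phenylsulfanyl brings no hydrogen-bond donor, where sulfo carried one. Within the data shown here, no measured step covers this exchange directly. Compound 1, with methyl at this position, gives a number, whereas the two compounds carrying a sulfonyl group both give only limits, so compound 4 is expected to move back toward a readable number, with an at least 1.6-fold lower number from compound 3 to compound 4 (0.22 log units; that floor lies within the scatter) as the expected step. For compound 4 the estimate is 6 mg/kg, within 2 mg/kg to 15 mg/kg, with a real chance that only a limit is reported again.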

Compound 4, dose for half-maximal effect: 4.5 mg/kg
For compound 4 the middle estimate is 1.3-fold (0.12 log units) above the measured one; low and high end bracket the measured number.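

Compound 4 shows that this place, on a saturated chain carbon, two bonds along the chain from an aromatic nitrogen, accepts a group with a six-membered aromatic ring: in this assay, phenylsulfanyl in place of methyl gives no change at the digits printed from compound 1 to compound 4 (within the scatter). The sulfur-linked ring also restores a readable number where the sulfonyl groups gave none, with an at least 2.2-fold lower number from compound 3 to compound 4 (0.34 log units; beyond the scatter) and an at least 2.2-fold lower number from compound 2 to compound 4 (0.34 log units; beyond the scatter). These two steps are floors and not full sizes, because compound 2 and compound 3 stand on a limit: the limit of > 10 mg/kg in this assay, at which 2 of the 4 values shown sit.

The compounds shown leave open whether the sulfur or the aromatic ring matters more in compound 4, and whether a sulfonyl group itself is what costs the effect. A phenylsulfonyl group or a benzyl group at the same place would separate these readings.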